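The source may report more compounds than this note shows. Statements on the series, on what has been measured and on what is new or still open speak of the compounds shown alone.

Measured in an ADME assay on microsomes from liver (Homo sapiens) for metabolic stability, with a stated time of 60 min, tested at 1 uM; a higher number here means that more of the compound is left, a lower number that less of the compound is left
- Compound 1 `COc1cccc(CN2C(=O)C(C3=NS(=O)(=O)c4cc(NS(C)(=O)=O)ccc4N3)=C(O)[C@@H]3[C@H]4CC[C@H](C4)[C@@H]32)c1` gives 61%
- Compound 2 `CS(=O)(=O)Nc1ccc2c(c1)S(=O)(=O)N=C(C1=C(O)[C@@H]3[C@@H]4CC[C@@H](C4)[C@@H]3N(Cc3ccccc3)C1=O)N2` gives 90%
- Compound 3 `CS(=O)(=O)Nc1ccc2c(c1)S(=O)(=O)N=C(C1=C(O)[C@@H]3[C@@H]4CC[C@@H](C4)[C@@H]3N(Cc3ccccc3F)C1=O)N2` gives 83%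

Compound 3 sits within the scatter of compound 2 and clearly above compound 1. Compound 4 `COc1cccc(CN2C(=O)C(C3=NS(=O)(=O)c4cc(NS(C)(=O)=O)ccc4N3)=C(O)[C@@H]3[C@@H]4CC[C@@H](C4)[C@@H]32)c1` keeps the core of compound 3 and changes one group: 3-methoxyphenyl in place of 2-fluorophenyl on a saturated chain carbon bound to an amide-type nitrogen in a ring. For the measured compounds named here, the only measured step is a number 7 percentage points lower from compound 2 to compound 3 (within the scatter), a fluoro-for-hydrogen swap that says little about so different a group. Compound 1 also carries the 3-methoxybenzyl group, with a different spatial arrangement in its core, and it gives 61%, so a moderate drop is expected. The expected step is a number 11 percentage points lower from compound 3 to compound 4 (beyond the scatter). Compound 4 is estimated at 72%, with an expected range from 55% to 88%.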

Compound 4, percent of the compound remaining: 83%
Beside the measured number, compound 4's estimate is 11 percentage points below it; the measured number falls inside the stated range.
By their numbers in this assay, from the lowest: compound 1; then compounds 3, 4 and 2 (each within the scatter of the next).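

In this assay, exchanging the group at this position gives no change at the digits printed from compound 3 to compound 4 (within the scatter), and adding the methoxy group to the benzyl group of compound 2 gives a number 7 percentage points lower from compound 2 to compound 4 (within the scatter). So this position accepts all three benzyl groups shown within the scatter. The one clear step, a number 22 percentage points higher from compound 1 to compound 4 (beyond the scatter), therefore points to the core's configuration rather than the methoxy group: the fact that compounds 1 and 4 differ only in the configuration as drawn

From the compounds shown here alone, whether the same configuration gap appears with the unsubstituted benzyl or 2-fluorobenzyl group remains open. So does how an amine or a carboxylic acid on the aromatic ring would fare here.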